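Two trifluoromethyl groups on the amide ring and cytotoxicity

The source may report more compounds than this note shows. Statements on the series, on what has been measured and on what is new or still open speak of the compounds shown alone.

The series rests on an anilide core bearing a sulfonamide. Compound 1 `COc1cc(NC(=O)c2cccc(C(F)(F)F)c2)ccc1NS(C)(=O)=O` carries one trifluoromethyl on the benzoyl ring, and in an ADME assay on RAW264.7 cells (Mus musculus) for cytotoxicity, read by MTT assay, with a stated time of 48 h (on this read-out higher numbers stand for weaker inhibition and lower numbers for stronger inhibition), compound 1 gives 84800 nM. Compound 2 `COc1cc(NC(=O)c2cc(C(F)(F)F)cc(C(F)(F)F)c2)ccc1NS(C)(=O)=O` differs from it by the change (trifluoromethyl in place of hydrogen on an aromatic carbon). In this assay compound 2 reaches only a limit of the assay, > 250000 nM, so no number is known for it. The measured step is an at least 2.9-fold higher number from compound 1 to compound 2 (0.46 log units; beyond the scatter), which stands on (the limit of > 250000 nM in this assay, at which 1 of the 3 values shown sits).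

Compound 3 `CCS(=O)(=O)Nc1ccc(NC(=O)c2cccc(C(F)(F)F)c2)cc1F` has a different core; the difference between the two cores of compound 1 and compound 3 is not broken down here. In this assay compound 3 gives 119000 nM, and the gap between compound 3 and compound 1 is within the scatter of this assay, so no order between them is claimed.

Compound 4 `CCS(=O)(=O)Nc1ccc(NC(=O)c2cc(C(F)(F)F)cc(C(F)(F)F)c2)cc1F` has not been measured. It differs from compound 3 by trifluoromethyl in place of hydrogen on an aromatic carbon, which is the same change that turns compound 1 into compound 2, at a place described in the same words. The expectation for compound 4 therefore follows that single measured step: in this assay the step from compound 3 to compound 4 is estimated as a 2.7-fold higher number from compound 3 to compound 4 (0.43 log units; beyond the scatter), because compound 1 to compound 2 gave an at least 2.9-fold higher number from compound 1 to compound 2 (0.46 log units; beyond the scatter). The number for compound 4 in this assay is thus expected near 320000 nM, between 150000 nM and 700000 nM, with a fair chance that only a limit is reported.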

Compound 4, half-maximal inhibitory concentration: > 250000 nM
Compound 4 ended at the assay's limit; the forecaster's own chance of this, stated with the estimate: 65%; the middle value does not contradict the limit.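

Carrying the change to the second core gave the same direction of result in this assay, with an at least 2.1-fold higher number from compound 3 to compound 4 (0.32 log units; beyond the scatter), so on the two cores shown a second trifluoromethyl on the amide ring goes with a higher number, that is, weaker inhibition: the same change on two cores in this assay, an at least 2.9-fold higher number (0.46 log units; beyond the scatter) from compound 1 to compound 2 and an at least 2.1-fold higher number (0.32 log units; beyond the scatter) from compound 3 to compound 4; the limit leaves it open whether they differ Compound 4 gives > 250000 nM, which is a limit of the assay and not a number. This does not show that the change has the same size on both cores, nor what its true size is on either one, since neither step ends on a measured number: the limit of > 250000 nM in this assay, at which 2 of the 4 values shown sit.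

The compounds shown leave open how far the numbers for compound 2 and compound 4 actually lie beyond the limit, and whether the change would act in the same direction on any core other than these two. They also leave open what a different group at the same place on the ring, such as an amine, a carboxylic acid or a longer chain, would do to the number in this assay.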